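The source may hold more compounds than are shown below. What is called first, only, known or untested is meant among the compounds shown, and "the series" means these compounds.

Measured compounds in an assay on cells for inhibition of Palmitoleoyl-protein carboxylesterase NOTUM variant C330S (Homo sapiens), read by fluorescence, with a stated time of 40 min; a lower number here means a stronger inhibitor, a higher number a weaker inhibitor:
compound 1 `Cc1cc(C(=O)O)c(C)n1-c1ccc(Cl)c(C(F)(F)F)c1`, compound 1 gives 2100 nM
compound 2 `Cc1cc(C(=O)O)c(C)n1-c1cccc(C(F)(F)F)c1`, compound 2 gives 1500 nM

Within the data shown here, compound 2 and compound 1 sit within the scatter of one another in this assay; the only measured step, a 1.4-fold lower number from compound 1 to compound 2 (0.15 log units; within the scatter), carries no rankable difference.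

Compound 3 `COc1cccc(-n2c(C)cc(C(=O)O)c2C)c1` differs from compound 2 by methoxy in place of trifluoromethyl on an aromatic carbon. Among the measured compounds shown here, no measured step changes the trifluoromethyl group, so nothing bears directly on this exchange; the one step available concerns a chloro and was within the scatter. The direction is therefore uncertain, and a step beyond the scatter cannot be ruled out in either sense.

Compound 3 is expected at 4000 nM, within 1200 nM to 13000 nM. That estimate corresponds to an expected 2.7-fold higher number from compound 2 to compound 3 (0.43 log units; beyond the scatter).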

Compound 3, half-maximal inhibitory concentration: 1500 nM
For compound 3 the middle estimate is 2.7-fold (0.43 log units) above the measured one, and the stated range covers the measured number.
By their numbers in this assay, from the lowest: compounds 2, 3 and 1 (each within the scatter of the next).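

In this assay, among these compounds, methoxy in place of trifluoromethyl on the aromatic carbon, meta to a large group, gives no change at the digits printed from compound 2 to compound 3 (within the scatter) and is the first measured exchange of the trifluoromethyl group. The two groups cannot be ranked at this position, although they differ in heavy atoms and hydrogen-bond acceptors. No supporting data bear on why the number stays the same.

Still open, from the compounds shown here alone, is whether an amine or a longer chain at this position would stay within the scatter of compound 2 . Also open, going by these compounds, is whether plain hydrogen here would do the same.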